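From Chloro to Hydrogen on the Shared Core

The source may report more compounds than this note shows. Statements on the series, on what has been measured and on what is new or still open speak of the compounds shown alone.

Compound 1 `CC(C)(c1cccnc1)C(O)c1ccccc1` and compound 2 `CC(C)(c1cccnc1)C(Cl)c1ccccc1` share one core and differ only at a single chain carbon. In a functional assay for inhibition of cytochrome P450 11B1, mitochondrial (Bos taurus) (on this read-out lower numbers stand for stronger inhibition and higher numbers for weaker inhibition), compound 1 gives 1530 nM and compound 2 gives 1630 nM; compound 2 stands highest of the two numbers shown, yet only within the scatter of compound 1. Among the compounds with values here, the one measured step, a 1.1-fold higher number from compound 1 to compound 2 (0.03 log units; within the scatter), altered little. Compound 3 `CC(C)(Cc1ccccc1)c1cccnc1` carries the change (hydrogen in place of chloro on a saturated chain carbon bound to an aromatic carbon and a saturated chain carbon). The step of a 1.0-fold higher number from compound 2 to compound 3 (0.02 log units; within the scatter) is expected to be small because the comparable swap a 1.1-fold higher number from compound 1 to compound 2 (0.03 log units; within the scatter) stayed within the scatter. Compound 3 is therefore estimated at 1700 nM, within a range from 700 nM to 4000 nM.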

Compound 3, half-maximal inhibitory concentration: 660 nM
For compound 3 the middle estimate is 2.6-fold (0.41 log units) above the measured one, and the stated range ends above it.
By their numbers in this assay, from the lowest: compound 3; then compounds 1 and 2 (each within the scatter of the next).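

Carrying either hydroxy or chloro on this saturated chain carbon gives much the same number in this assay and so the position could have seemed indifferent to change. Replacing either group with hydrogen shows otherwise, giving a 2.5-fold lower number from compound 2 to compound 3 (0.39 log units; beyond the scatter) and a 2.3-fold lower number from compound 1 to compound 3 (0.37 log units; beyond the scatter) as modest steps that both lie beyond the scatter. Nothing available here explains this difference.

On these data alone, it remains open whether a smaller group such as fluoro, or a methyl or an amine at the same carbon, would read like hydrogen or like hydroxy and chloro.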